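A few compounds are considered here, and "the series" means these few. Any claim that something is new, unique, unknown or untested is made for them only; others in the source may bear on it.

Compound 3 `Cc1ccc(NC(=O)NC2CCN(c3ncnc4[nH]ncc34)CC2)cc1` is a urea that in an assay on isolated protein for inhibition of serine/threonine-protein kinase PAK 1 (Homo sapiens), read by ADP-Glo, with a stated time of 40 min (on this read-out lower numbers stand for stronger inhibition and higher numbers for weaker inhibition), gives 4710 nM. Among the three compounds measured it holds the second highest number: compound 2 `O=C(NC1CCN(c2ncnc3[nH]ncc23)CC1)c1ccccc1Cl` gives 5240 nM, and compound 1 `O=C(NC1CCN(c2ncnc3[nH]ncc23)CC1)c1cccc(C(F)(F)F)c1` gives 2510 nM, and both of these sit within the scatter of the value of compound 3, so no order can be read among them. Going by the values given here, the only measured step that bears on the present change is a 1.1-fold lower number from compound 2 to compound 3 (0.05 log units; within the scatter), in which (4-methylphenyl)amino replaced 2-chlorophenyl on a carbonyl carbon, and it did not move the number beyond the scatter. Compound 4 `O=C(Nc1ccc(F)cc1F)NC1CCN(c2ncnc3[nH]ncc23)CC1` carries 2,4-difluorophenyl in place of 4-methylphenyl on an amide-type nitrogen. Among the compounds with values here, no measured pair varies only the substituents of the aryl ring on the urea nitrogen, so the data give no direction for this change, and the one related step was flat. Compound 4 is therefore expected to give 4200 nM in this assay, within a range from 1500 nM to 12000 nM. This means an expected step of a 1.1-fold lower number from compound 3 to compound 4 (0.05 log units; within the scatter), not beyond the scatter.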

Compound 4, half-maximal inhibitory concentration: 1140 nM
For compound 4 the middle estimate is 3.7-fold (0.57 log units) above the measured one; measured number below the stated range.
By their numbers in this assay, from the lowest: compound 4; then compounds 1, 3 and 2 (each within the scatter of the next, the first and the last beyond it).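

In this assay the aryl group on the urea nitrogen proves able to move the number: with 2,4-difluorophenyl in place of 4-methylphenyl on an amide-type nitrogen, the result is a 4.1-fold lower number from compound 3 to compound 4 (0.62 log units; beyond the scatter), a step beyond the scatter. Replacing 2-chlorophenyl on a carbonyl carbon with (2,4-difluorophenyl)amino likewise gives a 4.6-fold lower number from compound 2 to compound 4 (0.66 log units; beyond the scatter), whereas (4-methylphenyl)amino in that place gave only a 1.1-fold lower number from compound 2 to compound 3 (0.05 log units; within the scatter), so the urea link alone does not set the number and the aryl group it carries counts. Nothing shown here explains the difference between these two aryl groups.

From the compounds shown here alone, whether 2-fluorophenyl or 4-fluorophenyl alone would give the same step remains open. So does how an aryl ring bearing an amine or a carboxylic acid would read.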